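The source may hold more compounds than are shown below. What is called first, only, known or untested is meant among the compounds shown, and "the series" means these compounds.

Among the compounds with values here, compound 1, `O=Cc1c(-c2ccc([N+](=O)[O-])cc2)nc2sc(Cc3ccccc3)nn12`, is the lower of the two numbers so far in a functional assay on cells (Cancer cell lines, Homo sapiens) for inhibition (a lower number here means a stronger inhibitor of growth, a higher number a weaker inhibitor of growth), where compound 1 gives 58900 nM. Within the data shown here, compound 2, `O=[N+]([O-])c1ccc(-c2nc3sc(Cc4ccccc4)nn3c2Br)cc1`, is its only neighbour, and in this assay compound 2 gives 64600 nM; the step of a 1.1-fold higher number from compound 1 to compound 2 (0.04 log units; within the scatter) is within the scatter, so the two stand level.

Compound 3, `O=Cc1c(-c2ccc(Br)cc2)nc2sc(Cc3ccccc3)nn12`, differs from compound 1 by bromo in place of nitro on an aromatic carbon. Among the measured compounds shown here, no measured step touches this nitro-bearing ring; the only step available, from compound 1 to compound 2, exchanges a group elsewhere on the shared core and stayed within the scatter. Both measured numbers sit close together, and nothing in the series points to a direction for the change to bromo. The expectation for compound 3 in this assay is therefore no step beyond the scatter, a 1.1-fold lower number from compound 1 to compound 3 (0.03 log units; within the scatter). Compound 3 is estimated at 55000 nM, with a range from 20000 nM to 150000 nM.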

Compound 3, concentration for total growth inhibition: 20000 nM
Estimate against measurement, compound 3: 2.8-fold (0.44 log units) above, and the stated range covers the measured number.
By their numbers in this assay, from the lowest: compound 3; then compounds 1 and 2 (each within the scatter of the next).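

In this assay, within the data shown here, the position para to a large group on the six-membered aromatic ring of carbon only gives the first step that clears the scatter: bromo in place of nitro gives a 2.9-fold lower number from compound 1 to compound 3 (0.47 log units; beyond the scatter). Among these compounds, the only earlier step, a 1.1-fold higher number from compound 1 to compound 2 (0.04 log units; within the scatter), lay within the scatter, so the nitro group is not required for the growth inhibition seen with compound 1, and the single bromine atom gives a modest gain over it. No evidence is available on what lies behind this step.

Open, from the compounds shown here alone, is whether another halogen, such as chloro or fluoro, or an amine or a carboxylic acid at this position would follow bromo or nitro. Also open, going by these compounds, is whether the gain from bromo holds when the formyl group on the shared core is exchanged as well.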